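This account rests on a few compounds, and the source may have more. Where it says the series, first, only, none or still open, it means among the compounds named here.

Measured compounds:
compound 1 `COc1cc2ncnc(Nc3cccc(C#N)c3)c2cc1OC` — "not active" (no number reported)
compound 2 `OB(O)c1ccc2ncnc(Nc3cccc(Cl)c3)c2c1` — 7%

In an assay on isolated protein for inhibition of vascular endothelial growth factor receptor 1 (Homo sapiens), read by ELISA, with a stated time of 20 min, tested at 1 uM (a lower number here means less inhibition, a higher number more inhibition at the concentration tested (going by the name of the read-out)), compound 1 gives "not active" (no number reported), a result that carries no number, so compound 1 stands at no fixed point on the scale and can only be taken as showing little or no inhibition. Compound 2 gives 7% in this assay, a small value. Compound 3 `COC(=O)c1cccc(Nc2ncnc3cc(OC)c(OC)cc23)c1` has not yet been measured. It differs from compound 1 in one place: methoxycarbonyl in place of cyano on an aromatic carbon. Within the data shown here, no step between measured compounds is known that would show what such a change does in this assay. Given the low standing of compound 1 and the small value of compound 2, no step beyond the scatter is expected from compound 1 to compound 3; a small value is expected for compound 3, or once more a result given without a number. Compound 3 is estimated at 6% in this assay, within a range from 0% to 25%.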

Compound 3, a percentage reported as inhibition, at one concentration (the size of the read-out at that concentration, not a potency): "not active" (no number reported)
Nothing numeric was reported for compound 3; no gap can be computed for the estimate.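

In this assay, among these compounds, compound 1 gives "not active" (no number reported) and compound 3 gives "not active" (no number reported) without a number, so no step from one to the other can be read. The compounds shown leave open whether methoxycarbonyl in place of cyano changes the result in this assay at all. No other information bears on this result.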